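The compounds below may be only part of what the source reports. "The series", "measured", "known", "first", "only" and "open" are said of these compounds alone.

Measured in an ADME assay on MDCK cells (Canis lupus familiaris) for cytotoxicity, read by MTT assay, with a stated time of 24 h; a lower number here means that less compound is tolerated, a higher number that more compound is tolerated:
Compound 1 `Cc1cc(CNS(=O)(=O)c2ccc([N+](=O)[O-])cc2)c(C)s1`: > 204000 nM
Compound 2 `Cc1cc(CNS(=O)(=O)c2ccc(Cl)cc2)c(C)s1`: 52900 nM
Compound 3 `N#Cc1ccc(S(=O)(=O)NCc2csc3ccccc23)cc1`: 122000 nM

The entry for compound 1 is a limit of the assay and not a number. Of the two actual numbers, compound 3 stands at 122000 nM and compound 2 stands at 52900 nM, so compound 3 has the higher number of the two.

Compound 4 `CC(=O)c1ccc(S(=O)(=O)NCc2csc3ccccc23)cc1` keeps the core of compound 3 and carries acetyl in place of cyano on an aromatic carbon, para to a large group: acetyl in place of cyano on an aromatic carbon. Among the measured compounds shown here, no measured step covers this exchange directly. The nearest guide is an at least 3.8-fold lower number from compound 1 to compound 2 (0.58 log units; beyond the scatter), with chloro in place of nitro on an aromatic carbon. That step belongs to the core of compound 1, involves neither cyano nor acetyl, and starts from the limit of > 204000 nM in this assay, at which 1 of the 3 values shown sits, so it gives only a loose hint that such an exchange can shift this assay. No step beyond the scatter is therefore expected, and the estimate is a 1.2-fold lower number from compound 3 to compound 4 (0.09 log units; within the scatter). For compound 4 the estimated value is 100000 nM, with an expected range from 45000 nM to 200000 nM.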

Compound 4, half-maximal cytotoxic concentration: > 193000 nM
Compound 4: only a limit was reported; the forecaster's own chance of this, stated with the estimate: 15%; middle value at least 1.9-fold (0.28 log units) away from the limit.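

Compound 4 gives a limit and not a number in this assay: the limit of > 193000 nM in this assay, at which 1 of the 4 values shown sits. With acetyl in place of cyano on an aromatic carbon, para to a large group, the result reads as an at least 1.5-fold higher number from compound 3 to compound 4 (0.19 log units; that floor lies within the scatter), so on this core the exchange brings no fall in the number, though how far the number rises is not fixed. Among the compounds shown here, the only earlier step, an at least 3.8-fold lower number from compound 1 to compound 2 (0.58 log units; beyond the scatter), went the other way, on a different core and with different groups, so a change of this kind does not always lower the number.

The compounds shown leave open how far the step from cyano to acetyl really reaches. They also leave open what an amine or a carboxylic acid would give at this position on the shared core.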